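Swapping the Aryl Group on the Hydrazone Carbon

The compounds below may be only part of what the source reports. "The series", "measured", "known", "first", "only" and "open" are said of these compounds alone.

This account follows three measured compounds and one not yet measured, all sharing the same core and differing only in the aryl group on a carbon with a double bond to nitrogen. In a functional assay on A549 cells (Homo sapiens) for cytotoxicity, read by MTT assay, with a stated time of 72 h (on this read-out higher numbers stand for weaker inhibition and lower numbers for stronger inhibition), compound 1 `COc1ccc(OC)c(/C=N/NC(=O)Nc2ccc(Oc3ccnc(-c4nncn4CCN(C)C)c3)c(F)c2)c1` gives 1950 nM. Compound 2 `COc1ccc(/C=N/NC(=O)Nc2ccc(Oc3ccnc(-c4nncn4CCN(C)C)c3)c(F)c2)c(OC)c1OC` gives 6680 nM in this assay, and compound 3 `CN(C)CCn1cnnc1-c1cc(Oc2ccc(NC(=O)N/N=C/c3ccccc3O[N+](=O)[O-])cc2F)ccn1` gives 1200 nM. Compound 1 thus stands second highest of the three numbers: the step from it to compound 3 is a 1.6-fold lower number from compound 1 to compound 3 (0.21 log units; within the scatter), while the step to compound 2 is a 3.4-fold higher number from compound 1 to compound 2 (0.53 log units; beyond the scatter).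

Compound 4 `CN(C)CCn1cnnc1-c1cc(Oc2ccc(NC(=O)N/N=C/c3ccc(F)cc3F)cc2F)ccn1` differs from compound 1 by 2,4-difluorophenyl in place of 2,5-dimethoxyphenyl on a carbon with a double bond to nitrogen. Both measured steps that change this aryl group bear on the expectation: one stays within the scatter, the other rises modestly. Since neither the nitrooxyphenyl nor the trimethoxyphenyl analogue informs directly on a difluorophenyl group, compound 4 is expected to stay close to compound 1, with the estimated step of a 1.2-fold lower number from compound 1 to compound 4 (0.09 log units; within the scatter). Compound 4 is therefore estimated at 1600 nM, within a range from 600 nM to 4500 nM.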

Compound 4, half-maximal inhibitory concentration: 1870 nM
Compound 4: middle estimate off by 1.2-fold (0.07 log units), on the low side; low and high end bracket the measured number.
By their numbers in this assay, from the lowest: compounds 3, 4 and 1 (each within the scatter of the next); then compound 2.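

In this assay, the change from 2,5-dimethoxyphenyl to 2,4-difluorophenyl gives a 1.0-fold lower number from compound 1 to compound 4 (0.02 log units; within the scatter), so at this position an aryl group with 0 hydrogen-bond acceptors reads the same as one with 2. Compound 4 also stays level with the nitrooxy analogue, at a 1.6-fold higher number from compound 3 to compound 4 (0.19 log units; within the scatter), but it separates from the trimethoxy analogue, at a 3.6-fold lower number from compound 2 to compound 4 (0.55 log units; beyond the scatter), which leaves the 2,3,4-trimethoxyphenyl group of compound 2 as the only one of the four aryl groups set apart from the other three. No evidence on the cause of these steps is at hand.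

The compounds shown leave open whether the unsubstituted phenyl group would read like compounds 1, 3 and 4. They also leave open whether an aryl group carrying an amine or a carboxylic acid would hold that level or move away from it as compound 2 does.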